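The source may hold more compounds than are shown below. What is called first, only, known or untested is meant among the compounds shown, and "the series" means these compounds.

Series notes. The shared core is that of compound 1 `N/C(=N\NC(=S)N1CCOCC1)c1ccccn1`, which in a functional assay on MCF7 cells (Homo sapiens) for cytotoxicity, read by MTT assay, with a stated time of 72 h, tested at 1 uM (on this read-out lower numbers stand for less inhibition of growth and higher numbers for more inhibition of growth at the one concentration tested), gives 14.7%. Two measured variants carry a methyl in place of hydrogen on an aromatic carbon: compound 2 `Cc1ccnc(/C(N)=N/NC(=S)N2CCOCC2)c1` gives 1.22%, and compound 3 `Cc1cccc(/C(N)=N/NC(=S)N2CCOCC2)n1` gives 11.7%. Compound 1 stands highest of the three numbers; the step of a number 13.5 percentage points lower from compound 1 to compound 2 (beyond the scatter) lies beyond the scatter, while the step of a number 3 percentage points lower from compound 1 to compound 3 (within the scatter) lies within it. Compound 4 `N/C(=N\NC(=S)N1CCCC1)c1ccccn1` has not yet been measured. It differs from compound 1 in one place: pyrrolidin-1-yl in place of morpholin-4-yl on a thiocarbonyl carbon. Among the measured compounds shown here, neither measured step bears on this change: both concern a methyl on an aromatic carbon and leave the group on the thiocarbonyl carbon untouched, and no measured pair varies that group. With nothing to go on beyond the value of compound 1 itself, the expected step in this assay is none beyond the scatter, in either direction, and the range must be kept wide. Compound 4 is therefore estimated at 14%, with a range from 2% to 28%. That estimate means an expected step of a number 0.7 percentage points lower from compound 1 to compound 4 (within the scatter), which is within the scatter.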

Compound 4, percent growth inhibition at one concentration: 45.9%
The estimate for compound 4 lay 31.9 percentage points below the measured number; measured number outside the range, above it.
By their numbers in this assay, from the lowest: compound 2; then compounds 3 and 1 (each within the scatter of the next); then compound 4.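

In this assay, among the compounds shown here, pyrrolidin-1-yl in place of morpholin-4-yl on a thiocarbonyl carbon gives a number 31.2 percentage points higher from compound 1 to compound 4 (beyond the scatter) and is the first measured variation of the group at this place. The earlier steps shown here, both methyl in place of hydrogen on an aromatic carbon, gave lower numbers or stayed within the scatter, whereas this change raises the number by a large step, so the read-out responds strongly to the group on the thiocarbonyl carbon. No measurement at hand accounts for the size of this step.

The step exchanges a six-membered ring with 2 hetero atoms and 1 hydrogen-bond acceptor for a five-membered ring with 1 hetero atom and 0 hydrogen-bond acceptors, so ring size and the ring oxygen change together, and piperidin-1-yl or an open-chain dimethylamino group would be needed to separate them. Also open, on these data alone, is whether the gain from pyrrolidin-1-yl carries over to the methyl-bearing variants, compound 2 and compound 3, since only the core of compound 1 carries it here.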